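The source may hold more compounds than are shown below. What is called first, only, known or untested is meant among the compounds shown, and "the series" means these compounds.

Compound 1 `CC(=O)OC(C)n1cnc2c(Cl)nc(I)nc21` is measured in a functional assay on WI-38 cells (Homo sapiens) for inhibition (a higher number here means a weaker inhibitor, a lower number a stronger inhibitor), where compound 1 gives 14100 nM. Compound 2 `CC(O)n1cnc2c(Cl)nc(I)nc21` differs from it by hydrogen in place of acetyl on an oxygen on a saturated carbon. In this assay compound 2 gives only a limit, > 500000 nM. That single change brought an at least 35-fold higher number from compound 1 to compound 2 (1.54 log units; beyond the scatter). Compound 3 `CC(=O)OC(C)n1cnc2c(S)nc(F)nc21` is built on a different core from compound 1; the difference between the two cores is not broken down here. In this assay compound 3 gives only a limit, > 500000 nM. Compound 4 `CC(O)n1cnc2c(S)nc(F)nc21` is not yet measured; it differs from compound 3 by hydrogen in place of acetyl on an oxygen on a saturated carbon, the same change at the same place as before. For compound 4 in this assay a step that the limit leaves unreadable from compound 3 to compound 4 is expected, because the limit of > 500000 nM in this assay, at which 2 of the 3 values shown sit, already holds compound 3 and the earlier step of an at least 35-fold higher number from compound 1 to compound 2 (1.54 log units; beyond the scatter) went toward weaker inhibition. Compound 4 is therefore estimated at 1000000 nM, most likely reported again only as a limit.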

Compound 4, half-maximal inhibitory concentration: > 500000 nM
Compound 4: a limit, no number; the forecaster's own chance of this, stated with the estimate: 90%; the middle value does not contradict the limit.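

No step can be read from compound 3 to compound 4, since each gives only a limit in this assay. The compounds shown leave open whether acetoxy to hydroxy weakens inhibition on this core as it does on the core of compound 1.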